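Two Ring Stereocentres Inverted in a Peroxide Acid

This account rests on a few compounds, and the source may have more. Where it says the series, first, only, none or still open, it means among the compounds named here.

Compound 1 `C=C1CCCC(C)(C)C1CC[C@]1(C)CC[C@@H]([C@@H](C)C(=O)O)OO1`: in a functional assay on 786-0 cells (Homo sapiens) for cytotoxicity, read by colony formation (on this read-out higher numbers stand for weaker inhibition of growth and lower numbers for stronger inhibition of growth), compound 1 gives > 5000 nM, a limit of the assay.
Compound 2 `C=C1CCCC(C)(C)C1(O)CC/C(C)=C/CC[C@]1(C)CC[C@H]([C@@H](C)C(=O)OC)OO1`: in this assay compound 2 gives > 5000 nM, also a limit.
Compound 3 `C=C1CCCC(C)(C)C1(O)CC/C(C)=C/CC[C@]1(C)CC[C@@H]([C@@H](C)C(=O)OC)OO1`: in this assay compound 3 gives > 5000 nM, again a limit.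

Compound 1 therefore stands only at a limit, and the two further values shown are limits as well. Compound 4 `C=C1CCCC(C)(C)C1CC[C@@]1(C)CC[C@H]([C@@H](C)C(=O)O)OO1` differs from it as follows: the two compounds have the same atoms and bonds; at least one stereo element is drawn with a configuration in one of them and without one in the other: 2 of 4 stereo elements differ; a stereocentre at a saturated ring carbon is drawn R in compound 1 and S in compound 4; a stereocentre at a saturated ring carbon is drawn S in compound 1 and R in compound 4. Among the compounds with values here, the one measured step between stereoisomers, a step that the two limits leave unreadable from compound 2 to compound 3, cannot be sized, since the limit of > 5000 nM in this assay, at which 3 of the 3 values shown sit, and the fact that one of compounds 2 and 3 is drawn with a defined configuration and the other without, at the place where they differ leave it unreadable. No direction or size beyond the scatter can thus be expected for the change from compound 1 to compound 4; compound 4 is expected to return a limit too. Compound 4 is estimated at 8000 nM, within 4000 nM to 20000 nM, an expected step that the limit leaves unreadable from compound 1 to compound 4.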

Compound 4, concentration for 50% growth inhibition: 940 nM
The estimate for compound 4 lay 8.5-fold (0.93 log units) above the measured number; measured number below the stated range.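

In this assay, inverting the two ring stereocentres, with atoms and bonds unchanged, gives an at least 5.3-fold lower number from compound 1 to compound 4 (0.72 log units; beyond the scatter). Compound 4 thus provides the first value shown that is not a limit, and configuration at these two ring carbons alone separates two compounds here. The full size of the step cannot be read, as one end of it is a limit: the limit of > 5000 nM in this assay, at which 3 of the 4 values shown sit.

Which of the two stereocentres carries the step remains open, since only their joint inversion is shown. Also open, on these data alone, is how compound 4 would respond if an amide replaced its carboxylic acid.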